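This account rests on a few compounds, and the source may have more. Where it says the series, first, only, none or still open, it means among the compounds named here.

Measured so far:
- compound 1, `O=C(/C=C1\CCc2ccc(F)cc21)NCCO`: 50%
- compound 2, `O=C(/C=C1\CCc2ccc(Br)cc21)NC1CC1`: 33%

Both compounds were tested in a functional assay on the whole organism with Mus musculus as the target, at a dose of 100 mg/kg by the intraperitoneal route; a higher number here means more inhibition at the dose given (going by the name of the read-out), a lower number less inhibition. Compound 1 gives 50%, and compound 2 gives 33%, the lower of the two numbers, a gap between them that lies beyond the usual scatter of this kind of measurement. For the measured compounds named here, the two compounds differ in more than one place, so their values show only that compound 1 sits higher than compound 2, not which change carries the difference.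

Compound 3, `O=C(/C=C1\CCc2ccc(F)cc21)NC1CC1`, has not yet been measured. It differs from compound 2 in a single place: fluoro in place of bromo on an aromatic carbon. Compound 3 shares its fluoro group with compound 1 and the rest of its structure with compound 2. Going by the values given here, no single-change step between measured compounds is available to set the size of this swap, so the expectation rests on the two measured values alone. For compound 3 a step of a number 9 percentage points higher from compound 2 to compound 3 (within the scatter) upward from compound 2 is expected in this assay, lying between the two measured numbers. Compound 3 is therefore estimated at 42%, with a range from 25% to 60%.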

Compound 3, a percentage reported as inhibition, in the whole organism at one dose (the size of the read-out at that dose, not a potency): 100%
Beside the measured number, compound 3's estimate is 58 percentage points below it; the whole stated range lies below it.
By their numbers in this assay, from the lowest: compound 2; then compound 1; then compound 3.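

In this assay, fluoro in place of bromo on the aromatic carbon gives a number 67 percentage points higher from compound 2 to compound 3 (beyond the scatter). With everything else held constant, this single-atom swap shows that the halogen at this position strongly affects the read-out, which the first two compounds could not show because they differ in more than one place. The amide side matters as well: with fluoro held constant, cyclopropyl in place of 2-hydroxyethyl on the amide-type nitrogen gives a number 50 percentage points higher from compound 1 to compound 3 (beyond the scatter), so the high number of compound 3 depends on both groups in this set. No measurement is available to explain either step.

The compounds shown leave open how chloro or a plain hydrogen on this aromatic carbon would compare with fluoro, and whether a longer chain or an amine-bearing chain on the amide-type nitrogen would match cyclopropyl. Each number also comes from a single dose, so these results describe the size of the effect at that dose, not potency.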